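This account rests on a few compounds, and the source may have more. Where it says the series, first, only, none or still open, it means among the compounds named here.

Of the compounds shown here, two sharing one core have so far been tested in a toxicity assay on NIH3T3 cells (Mus musculus) for cytotoxicity, read by resazurin assay; a higher number here means that more compound is needed for the effect, a lower number that less compound is needed. Compound 1 `COC(=O)c1ccc(NCc2cncn2Cc2ccc(Cl)cc2)cc1-c1ccccc1`, which carries a 4-chlorophenyl group, gives 25000 nM. Compound 2 `COC(=O)c1ccc(NCc2cncn2Cc2ccccc2Cl)cc1-c1ccccc1`, with a 2-chlorophenyl group instead, gives 10000 nM, the lower of the two numbers. Compound 3 `COC(=O)c1ccc(NCc2cncn2Cc2ccccc2N)cc1-c1ccccc1` keeps everything in compound 2 except one group, with amino in place of chloro on an aromatic carbon, ortho to a large group (amino in place of chloro on an aromatic carbon). For the measured compounds named here, no measured step swaps chloro for another group, so the evidence is indirect. Going by the values given here, the only guide is a 2.5-fold lower number from compound 1 to compound 2 (0.40 log units; beyond the scatter), a modest step that comes from changing 4-chlorophenyl to 2-chlorophenyl on the same part of the molecule. A step of similar modest size therefore seems a reasonable expectation in this assay, with only a weak lean towards a higher number and no firm support for either direction. The expected change is a 1.4-fold higher number from compound 2 to compound 3 (0.15 log units; within the scatter). For compound 3 the estimated value is 14000 nM, with an expected range from 5000 nM to 40000 nM.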

Compound 3, half-maximal effective concentration: 25000 nM
For compound 3 the middle estimate is 1.8-fold (0.25 log units) below the measured one, and the stated range covers the measured number.
By their numbers in this assay, from the lowest: compound 2; then compounds 1 and 3 (each within the scatter of the next).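

For the compounds shown here, compound 3 is the first direct exchange of the chloro group on this six-membered aromatic ring, ortho to a large group, and in this assay amino in place of chloro gives a 2.5-fold higher number from compound 2 to compound 3 (0.40 log units; beyond the scatter). The lower number of compound 2 therefore does not carry over to every group at this place: it holds with chloro, but not with amino, even though the two groups are the same size in heavy atoms, a single atom each. The comparison of the 2-aminophenyl and 4-chlorophenyl groups shows no change at the digits printed from compound 1 to compound 3 (within the scatter), so these two compounds cannot be told apart in this assay, and nothing in the available data explains the difference between chloro and amino at this place.

The compounds shown leave open whether a fluoro or a methoxy group at this same place would read like chloro in compound 2 or like amino in compound 3. They also leave open how a 4-aminophenyl group would compare with the 4-chlorophenyl group of compound 1, which would show whether the amino group behaves the same way elsewhere on the ring.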